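The source may hold more compounds than are shown below. What is called first, only, known or untested is meant among the compounds shown, and "the series" means these compounds.

Compound 1, `COc1ccc(S(=O)(=O)N(CC(N)=O)c2ccc(N(CC(N)=O)S(=O)(=O)c3ccc(SCCOCCOCCN=C=S)cc3)c3ccccc23)cc1`, stands at the assay ceiling in an ADME assay on cells (Peritoneal macrophage, Mus musculus) for cytotoxicity, read by CCK-8 assay, with a stated time of 24 h; a higher number here means that more compound is tolerated, a lower number that less compound is tolerated: compound 1 gives > 10000 nM, which is a limit of the assay and not a number. For the measured compounds named here, compound 2, `COc1ccc(S(=O)(=O)N(CC(N)=O)c2ccc(N(CC(N)=O)S(=O)(=O)c3ccc(SCCOCCOCCOCCN=C=S)cc3)c3ccccc23)cc1`, is the only other compound measured, and in this assay compound 2 gives > 10000 nM, again a limit. Going by the values given here, the one measured step, a step that the two limits leave unreadable from compound 1 to compound 2, therefore cannot be sized; all that can be said is the limit of > 10000 nM in this assay, at which 2 of the 2 values shown sit. Compound 3, `COc1ccc(S(=O)(=O)N(CC(N)=O)c2ccc(N(CC(N)=O)S(=O)(=O)c3ccc(S(=O)(=O)CCCCN=C=S)cc3)c3ccccc23)cc1`, differs from compound 1 by a group of 10 heavy atoms (5 carbon, 1 nitrogen, 2 oxygen, 2 sulfur; no ring) in place of a group of 12 heavy atoms (7 carbon, 1 nitrogen, 2 oxygen, 2 sulfur; no ring), on an aromatic carbon. Among the compounds with values here, no measured step of readable size bears on this change, so the expectation rests only on both measured values sitting at the limit. The step that the limit leaves unreadable from compound 1 to compound 3 is expected to lie within the scatter, and compound 3 is expected to be tolerated at a concentration of about 15000 nM, between 7000 nM and 30000 nM, most likely reported again as a limit.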

Compound 3, half-maximal cytotoxic concentration: > 10000 nM
Compound 3: only a limit was reported; the forecaster's own chance of this, stated with the estimate: 80%; the middle value does not contradict the limit.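

No step can be read between compound 1 and compound 3, since both stand at a limit of this assay and not at a number: the limit of > 10000 nM in this assay, at which 3 of the 3 values shown sit. The compounds shown leave open at what concentration any of them stops being tolerated, and whether these chain changes alter that concentration.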